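Chloro for Carbamoyl on the Benzyl Group

The source may hold more compounds than are shown below. What is called first, only, known or untested is meant among the compounds shown, and "the series" means these compounds.

Three compounds sharing one core have been examined in an assay for inhibition of MAP kinase-interacting serine/threonine-protein kinase 1 (Homo sapiens), read by luminescence and ADP-Glo, with a stated time of 2 h; on this read-out higher numbers stand for weaker inhibition and lower numbers for stronger inhibition. Compound 1 `Nc1n[nH]c2cc(-c3ccc(=O)n(Cc4ccccc4)c3)ccc12` carries an unsubstituted benzyl group and gives 79 nM in this assay. Compound 2 `NC(=O)c1ccccc1Cn1cc(-c2ccc3cn[nH]c3c2)ccc1=O` bears a carbamoyl on that benzyl ring, and in this assay compound 2 gives 878 nM, the highest of the two numbers reported; the gap to compound 1 lies beyond the scatter. Compound 3 `Cn1ncc2ccc(-c3ccc(=O)n(Cc4ccccc4)c3)cc21`, which differs in the core, reaches only a limit of the assay, > 2000 nM in this assay, and is recorded as a limit rather than a number (the limit of > 2000 nM in this assay, at which 1 of the 3 values shown sits).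

Compound 4 `O=c1ccc(-c2ccc3cn[nH]c3c2)cn1Cc1ccccc1Cl` has not yet been measured. It differs from compound 2 in one place (chloro in place of carbamoyl on an aromatic carbon), the new group sitting ortho to a large group on a six-membered aromatic ring of carbon only. Since compound 1, lacking any substituent on that ring, gives 79 nM, the step from the carbamoyl-bearing compound 2 is expected to run downward toward stronger inhibition, of the size a 4.9-fold lower number from compound 2 to compound 4 (0.69 log units; beyond the scatter). Compound 4 is accordingly estimated at 180 nM in this assay, within a range from 50 nM to 600 nM.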

Compound 4, half-maximal inhibitory concentration: 80 nM
Compound 4: the middle estimate sits 2.3-fold (0.35 log units) above what was measured, and the stated range covers the measured number.
By their numbers in this assay, from the lowest: compounds 1 and 4 (each within the scatter of the next); then compound 2. At a limit, above all of these: compound 3.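

In this assay, within the data shown here, replacing carbamoyl with chloro on an aromatic carbon, ortho to a large group, gives an 11-fold lower number from compound 2 to compound 4 (1.04 log units; beyond the scatter), the first step read between compounds that differ in one place. Among these compounds, compound 1 and compound 2 differ in more than one place, so only this pair ties the higher number of compound 2 to the carbamoyl group. It also shows that a substituent at this position does not by itself bring that higher number, since the outcome depends on which group sits there.

The compounds shown leave open how a methoxy group, an amine or a carboxylic acid at this position would compare on the same core, and how an unsubstituted benzyl group would read there. No measurement shown bears on the cause of this step.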